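Piperazin-1-yl in place of dimethylamino: outlook for compound 4

The source may report more compounds than this note shows. Statements on the series, on what has been measured and on what is new or still open speak of the compounds shown alone.

Measured compounds:
compound 1, `O=C1N=C(Nc2ccccc2)S/C1=C/c1ccc(N2CCNCC2)cc1`, > 100000 nM in a functional assay on H460/TaxR cells (Homo sapiens) for cytotoxicity, read by sulforhodamine B assay, with a stated time of 48 h (a higher number here means that more compound is needed for the effect, a lower number that less compound is needed), a limit of the assay.
compound 2, `O=C1N=C(N(c2ccccc2)c2ccccc2)S/C1=C/c1ccc(N2CCNCC2)cc1`, > 100000 nM in this assay, a limit of the assay.
compound 3, `CN(C)c1ccc(/C=C2/SC(N(C)c3ccccc3)=NC2=O)cc1`, 160 nM in this assay.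

Within the data shown here, compound 3 holds the only actual number in this assay; the other two results are limits, at the limit of > 100000 nM in this assay, at which 2 of the 3 values shown sit. The step that the two limits leave unreadable from compound 1 to compound 2 cannot be read, as both ends are limits. Compound 4, `CN(C1=NC(=O)/C(=C\c2ccc(N3CCNCC3)cc2)S1)c1ccccc1`, is not yet measured. It differs from compound 3 by piperazin-1-yl in place of dimethylamino on an aromatic carbon. Among the measured compounds shown here, no measured step covers this exact exchange. What the values show is that compound 1 and compound 2, which both carry piperazin-1-yl on that aromatic carbon, give only limits in this assay, whereas compound 3 with dimethylamino gives a number. Compound 4 is therefore expected to need far more compound than compound 3, with the step of a 190-fold higher number from compound 3 to compound 4 (2.27 log units; beyond the scatter) large and toward weaker cytotoxicity, and a fair chance that only a limit is reported. For compound 4 the estimate is 30000 nM, within the range 3000 nM to 100000 nM.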

Compound 4, half-maximal effective concentration: > 100000 nM
Compound 4: only a limit was reported; the forecaster's own chance of this, stated with the estimate: 50%; middle value at least 3.3-fold (0.52 log units) from the limit.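

Piperazin-1-yl in place of dimethylamino on an aromatic carbon now has a readable size: in this assay the exchange gives an at least 620-fold higher number from compound 3 to compound 4 (2.79 log units; beyond the scatter). Compound 1 and compound 2 each differ from compound 3 in more than one place, so neither could tie the loss to this exchange alone. All the piperazin-1-yl compounds shown now stand at the same limit: the limit of > 100000 nM in this assay, at which 3 of the 4 values shown sit.

As far as these compounds go, the steps among compound 1, compound 2 and compound 4 cannot be read, as both ends of each are limits, so it stays open whether hydrogen, methyl or phenyl on the nitrogen on an aromatic ring matters when piperazin-1-yl is present. Also open, from the compounds shown here alone, is how morpholine, piperidine, 4-methylpiperazine or diethylamino would fare on the same aromatic carbon.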